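Methoxy for trifluoromethoxy on the aniline of the shared core

The source may hold more compounds than are shown below. What is called first, only, known or untested is meant among the compounds shown, and "the series" means these compounds.

Among the compounds with values here, compound 2 `CCS(=O)(=O)Nc1cc(-c2ccc3ncnc(Nc4ccc(OC(F)(F)F)cc4)c3c2)cnc1OC` is the weaker of the two measured members: in a functional assay on HCT-116 cells (Homo sapiens) for cytotoxicity, read by sulforhodamine B assay, with a stated time of 72 h (a lower number here means a stronger inhibitor, a higher number a weaker inhibitor), compound 2 gives 16600 nM, the highest of the two numbers. Within the data shown here, its nearest neighbour is compound 1 `CCS(=O)(=O)Nc1cc(-c2ccc3ncnc(Nc4ccc(F)cc4)c3c2)cnc1OC`, which in this assay gives 3160 nM; the single change from fluoro to trifluoromethoxy on an aromatic carbon reads a 5.3-fold higher number from compound 1 to compound 2 (0.72 log units; beyond the scatter).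

Compound 3 `CCS(=O)(=O)Nc1cc(-c2ccc3ncnc(Nc4ccc(OC)cc4)c3c2)cnc1OC` has not yet been measured. The change from compound 2 is methyl in place of trifluoromethyl on an oxygen on an aromatic ring; one bond further out, it reads trifluoromethoxy to methoxy, 4-(trifluoromethoxy)phenyl to 4-methoxyphenyl.

Among the measured compounds shown here, only one measured step bears on this position, a 5.3-fold higher number from compound 1 to compound 2 (0.72 log units; beyond the scatter), and it runs in the opposite sense: a small fluoro substituent replaced by trifluoromethoxy raised the number. Going from trifluoromethoxy to methoxy removes most of that added bulk but not all of it, so a step back towards compound 1 is expected, though probably not the full way. The expected step in this assay is a 2.6-fold lower number from compound 2 to compound 3 (0.41 log units; beyond the scatter). For compound 3 the estimate in this assay is 6500 nM, with a range from 2200 nM to 20000 nM.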

Compound 3, half-maximal inhibitory concentration: 3490 nM
Estimate against measurement, compound 3: 1.9-fold (0.27 log units) above, within the range that was stated.
By their numbers in this assay, from the lowest: compounds 1 and 3 (each within the scatter of the next); then compound 2.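

In this assay, the step of a 4.8-fold lower number from compound 2 to compound 3 (0.68 log units; beyond the scatter) sets methyl against trifluoromethyl on the same oxygen on an aromatic ring, and it places compound 2 apart from the other two compounds, with its steps to both printed as beyond the scatter. The step of a 1.1-fold higher number from compound 1 to compound 3 (0.04 log units; within the scatter) lies within the scatter, so methoxy and fluoro on this aromatic carbon cannot be told apart here, and the oxygen alone does not carry the higher number of compound 2; among these three compounds, the departure appears only when the trifluoromethyl group is present.

The compounds shown leave open whether the higher number follows the full set of three fluorines or would also appear with a partly fluorinated group such as difluoromethoxy, and whether a longer chain such as ethoxy would stay with compounds 1 and 3 or move towards compound 2. They also leave open how an amine or a carboxylic acid at this position would read, and whether the same order would hold on any other cell line. The data in hand offer no measurement that explains the difference between trifluoromethoxy and methoxy.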